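Butoxy Replacing Biaryl on the Sulfonamide Aryl Group

The source may report more compounds than this note shows. Statements on the series, on what has been measured and on what is new or still open speak of the compounds shown alone.

Of the compounds shown here, three sharing one core have been measured in a functional assay on DLD-1 cells (Homo sapiens) for antiproliferative activity, read by CellTiter-Glo, with a stated time of 72 h; on this read-out higher numbers stand for weaker inhibition and lower numbers for stronger inhibition. Compound 1 `CC1CCN(C2CCN(S(=O)(=O)c3cccc(Br)c3)CC2)CC1` gives 3.2 nM, compound 2 `CC1CCN(C2CCN(S(=O)(=O)c3ccc(F)cc3F)CC2)CC1` gives 102 nM, and compound 3 `COc1ccccc1-c1ccc(S(=O)(=O)N2CCC(N3CCC(C)CC3)CC2)cc1` gives 26 nM. Compound 3 thus stands second highest of the three numbers, between compound 2 above it and compound 1 below it, with both gaps beyond the scatter.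

For the measured compounds named here, the only step between measured compounds that differ in one place is a 32-fold higher number from compound 1 to compound 2 (1.50 log units; beyond the scatter), a change of the aryl group on the sulfonyl sulfur. It shows that substitution on that aryl ring can move this assay by a large amount.

Compound 4 `CCCCOc1ccc(S(=O)(=O)N2CCC(N3CCC(C)CC3)CC2)cc1` differs from compound 3 by butoxy in place of 2-methoxyphenyl on an aromatic carbon. Going by the values given here, this change is also on the aryl group attached to the sulfonyl sulfur, so the step from compound 1 to compound 2 bears on it, but only loosely: no measured pair exchanges an aryl substituent for an alkoxy chain. A step of moderate size in either direction is possible, and the direction cannot be read from the data.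

Compound 4 is therefore expected to give about 40 nM, within 10 nM to 160 nM, a step of a 1.5-fold higher number from compound 3 to compound 4 (0.19 log units; within the scatter) that is estimated with low confidence.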

Compound 4, half-maximal inhibitory concentration: 2300 nM
The estimate for compound 4 lay 58-fold (1.76 log units) below the measured number, and the stated range ends below it.
By their numbers in this assay, from the lowest: compound 1; then compound 3; then compound 2; then compound 4.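

In this assay, exchanging the 2-methoxyphenyl group for butoxy on an aromatic carbon, para to a large group, is far from a neutral swap: it gives an 88-fold higher number from compound 3 to compound 4 (1.95 log units; beyond the scatter) and places compound 4 highest of the four numbers. The earlier step, a 32-fold higher number from compound 1 to compound 2 (1.50 log units; beyond the scatter), had shown only that substituents on the aryl ring can move this assay, whereas this one shows that a large change also follows when a group holding a six-membered aromatic ring gives way to an open chain with no ring, even though the hydrogen-bond acceptor and donor counts stay the same. Nothing measured here explains why the number rises so far.

The change removes the ring and lowers the heavy-atom count at once, so the compounds shown leave open which of the two goes with the step. Unsubstituted phenyl at this position would keep the ring without the methoxy, while methoxy or a longer hexyloxy chain would vary the chain alone, and an amine or a carboxylic acid here remains an open question as well.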